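Chloro on the phenyl of compound 2: a small step

This account rests on a few compounds, and the source may have more. Where it says the series, first, only, none or still open, it means among the compounds named here.

Measured so far:
compound 1 `O=C1CC(O)CC(CSc2nc(-c3ccccc3)c(-c3ccccc3)[nH]2)O1` — 910 nM
compound 2 `c1ccc(-c2nc(SCC3CCCCO3)[nH]c2-c2ccccc2)cc1` — 210 nM

Compound 1 `O=C1CC(O)CC(CSc2nc(-c3ccccc3)c(-c3ccccc3)[nH]2)O1` and compound 2 `c1ccc(-c2nc(SCC3CCCCO3)[nH]c2-c2ccccc2)cc1` have been measured in an assay on microsomes from liver for inhibition of sterol O-acyltransferase 1 (Rattus norvegicus); on this read-out higher numbers stand for weaker inhibition and lower numbers for stronger inhibition. Compound 1 gives 910 nM. Among the compounds with values here, compound 2 gives 210 nM, the lower of the two numbers; the only step measured, a 4.3-fold lower number from compound 1 to compound 2 (0.64 log units; beyond the scatter), swaps the oxygen-rich ring of compound 1 for the plainer six-membered ring of compound 2.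

Compound 3 `Clc1cccc(-c2[nH]c(SCC3CCCCO3)nc2-c2ccccc2)c1` has not been measured. It differs from compound 2 by chloro in place of hydrogen on an aromatic carbon; cut one bond further out, phenyl becomes 3-chlorophenyl. No measured step touches either phenyl ring, so the one step shown bears on this change only indirectly, and nothing in the two numbers points in a particular direction. Compound 3 is therefore expected to stay close to compound 2, with a step of a 1.1-fold lower number from compound 2 to compound 3 (0.02 log units; within the scatter) that is not expected to go beyond the scatter. The estimate for compound 3 is 200 nM, with a range from 80 nM to 500 nM.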

Compound 3, half-maximal inhibitory concentration: 560 nM
Estimate against measurement, compound 3: 2.8-fold (0.45 log units) below; the measured number lies above the stated range.
By their numbers in this assay, from the lowest: compound 2; then compounds 3 and 1 (each within the scatter of the next).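

In this assay, within the data shown here, the one step that touches a phenyl ring goes upward, a 2.7-fold higher number from compound 2 to compound 3 (0.43 log units; beyond the scatter), so a single chloro in place of hydrogen on an aromatic carbon, meta to a large group, is enough to weaken inhibition beyond the scatter. The earlier step lay only in the six-membered non-aromatic ring on the saturated chain, with both phenyl rings bare, so it gave no reading of this ring; now phenyl to 3-chlorophenyl shows that this position is not indifferent to substitution, and compound 2 keeps the lowest number of the series. The compounds shown carry no information on why this single atom shifts the number in this direction.

On these data alone, a single substituent at a single place is all that is seen here, so it remains open whether a fluoro, a methyl or a methoxy at the same carbon would give a step of similar size and direction. As far as these compounds go, it is equally open whether chloro on the other phenyl ring, or an amine or a carboxylic acid on either ring, would raise the number as well.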